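The source may report more compounds than this note shows. Statements on the series, on what has been measured and on what is new or still open speak of the compounds shown alone.

Measured compounds:
Compound 1, `C=CC[C@H]1C[C@]2([C@@H](C)Cc3ccc(OC)c(C)c3)OCOC2=CC1=O`, 410 nM
Compound 2, `C=CC[C@H]1C[C@]2([C@@H](C)Cc3ccc(OC)c(C#N)c3)OCOC2=CC1=O`, 180 nM
Compound 3, `C=CC[C@H]1C[C@]2([C@@H](C)Cc3cc(C)c(OC)cc3F)OCOC2=CC1=O`, 230 nM

These three values come from a functional assay on M14 cells (Homo sapiens) for antiproliferative activity, with a stated time of 72 h; on this read-out higher numbers stand for weaker inhibition and lower numbers for stronger inhibition. Compound 2 differs from compound 1 by cyano in place of methyl on an aromatic carbon, and that change gave a 2.3-fold lower number from compound 1 to compound 2 (0.36 log units; beyond the scatter). The two cores differ by fluoro in place of hydrogen on an aromatic carbon, a change that gave a 1.8-fold lower number from compound 1 to compound 3 (0.25 log units; within the scatter). Compound 4, `C=CC[C@H]1C[C@]2([C@@H](C)Cc3cc(C#N)c(OC)cc3F)OCOC2=CC1=O`, is not yet measured in this assay. It differs from compound 3 by cyano in place of methyl on an aromatic carbon. Among the measured compounds shown here, this is the same kind of change as the one from compound 1 to compound 2, not the same: in compound 4 the place is also para to a fluoro group, which is not so in compound 2. Among the compounds shown, this change occurs twice in all, and only one of the two occurrences is measured. Resting on the step that this change gave in compound 2, a step of about a 2.2-fold lower number from compound 3 to compound 4 (0.34 log units; beyond the scatter) is expected. Compound 4 is therefore estimated at 105 nM, with a likely range from 50 nM to 230 nM.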

Compound 4, half-maximal inhibitory concentration: 37 nM
For compound 4 the middle estimate is 2.8-fold (0.45 log units) above the measured one; measured number outside the range, below it.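

In this assay, both changes lowered the number again on the second core, with a 6.2-fold lower number from compound 3 to compound 4 (0.79 log units; beyond the scatter) for cyano in place of methyl and a 4.9-fold lower number from compound 2 to compound 4 (0.69 log units; beyond the scatter) for fluoro in place of hydrogen, so in these compounds the direction carried over but the size did not. The cyano change did not transfer as a fixed increment between the two cores: the same change on two cores in this assay, a 2.3-fold lower number (0.36 log units; beyond the scatter) from compound 1 to compound 2 and a 6.2-fold lower number (0.79 log units; beyond the scatter) from compound 3 to compound 4, 2.7-fold (0.44 log units) apart, beyond the scatter of two such steps The four compounds form a single square, so the fluoro comparison shows the same departure from the other side rather than independent support, and it does not show whether the departure would recur on any other core: the same change on two cores in this assay, a 1.8-fold lower number (0.25 log units; within the scatter) from compound 1 to compound 3 and a 4.9-fold lower number (0.69 log units; beyond the scatter) from compound 2 to compound 4, 2.7-fold (0.44 log units) apart, beyond the scatter of two such steps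

The compounds shown leave open whether a carboxylic acid or an amide in place of the cyano group would also give a larger step when the fluoro group is present. They also leave open whether a chloro group in place of the fluoro group would enlarge the cyano step in the same way.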